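This account rests on a few compounds, and the source may have more. Where it says the series, first, only, none or still open, it means among the compounds named here.

compound 1 `Cc1ccc(S(=O)(=O)/C(=C/c2sccc2C)C(=O)c2ccc(Cl)cc2)cc1` gives 10000 nM
compound 2 `CCOc1ccc(/C=C(\C(=O)c2ccc(Cl)cc2)S(=O)(=O)Cc2ccc(F)cc2)cc1OC` gives 50000 nM
compound 3 `Cc1ccsc1/C=C(\C(=O)c1ccc(Cl)cc1)S(=O)(=O)Cc1ccc(F)cc1` gives 10000 nM

In a functional assay on DU-145 cells (Homo sapiens) for inhibition, read by trypan blue exclusion, with a stated time of 96 h (a higher number here means a weaker inhibitor of growth, a lower number a stronger inhibitor of growth), compound 3 gives 10000 nM and stands level with compound 1, the two together at the low end of the three numbers, while compound 2 gives 50000 nM as the highest. Compound 4 `Cc1ccsc1/C=C(\C(=O)c1ccc(Cl)cc1)S(=O)(=O)Cc1ccc(Cl)cc1` differs from compound 3 by a single change chloro in place of fluoro on an aromatic carbon in which chloro replaces fluoro on an aromatic carbon, para to a large group, so that 4-fluorobenzyl becomes 4-chlorobenzyl. Within the data shown here, no measured step makes this exchange. The closest evidence is no change at the digits printed from compound 1 to compound 3 (within the scatter) with 4-fluorobenzyl in place of 4-methylphenyl on the sulfonyl sulfur, a larger replacement of the same substituent that left the number unmoved. The modest 5.0-fold lower number from compound 2 to compound 3 (0.70 log units; beyond the scatter) belongs to the other substituent and bears on this change only weakly. No step beyond the scatter is therefore expected in this assay and no direction can be claimed. The expected size is a 1.1-fold lower number from compound 3 to compound 4 (0.05 log units; within the scatter) in this estimate. For compound 4 the estimated value is 9000 nM with an expected range from 3500 nM to 22000 nM in this measurement.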

Compound 4, concentration for 50% growth inhibition: 25000 nM
Compound 4: middle estimate off by 2.8-fold (0.44 log units), on the low side; the whole stated range lies below it.
By their numbers in this assay, from the lowest: compounds 1 and 3 (each within the scatter of the next); then compounds 4 and 2 (each within the scatter of the next).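

Exchanging 4-fluorobenzyl for 4-chlorobenzyl on the sulfonyl sulfur moves the number in this assay beyond the scatter (a 2.5-fold higher number from compound 3 to compound 4 (0.40 log units; beyond the scatter)), so this position does respond to a change of substituent, which the unmoved step between compound 1 and compound 3 had not shown. The comparison with compound 1 gives the same picture (a 2.5-fold higher number from compound 1 to compound 4 (0.40 log units; beyond the scatter)): 4-fluorobenzyl stands level with 4-methylphenyl here, while 4-chlorobenzyl does not. Nothing shown gives a reason for this difference.

The compounds shown leave open whether a bromo, a methoxy or an amine on the same aromatic carbon would fall level with compound 3 or with compound 4. They also leave open whether the chloro-for-fluoro step would hold with the 4-ethoxy-3-methoxyphenyl of compound 2 in place of 3-methylthiophen-2-yl.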